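Swapping a bromophenyl for a dichlorophenyl on the sulfonamide

The source may hold more compounds than are shown below. What is called first, only, known or untested is meant among the compounds shown, and "the series" means these compounds.

Measured compounds:
compound 1, `CC1CCN(C2CCN(S(=O)(=O)c3ccccc3Br)CC2)CC1`, 3 nM
compound 2, `CC1CCN(C2CCN(S(=O)(=O)c3ccccc3-c3ccccc3)CC2)CC1`, 0.96 nM
compound 3, `COc1ccc(-c2ccccc2S(=O)(=O)N2CCC(N3CCC(C)CC3)CC2)cc1`, 1000 nM

All three share one core and differ only in the aromatic group attached to the sulfonyl sulfur. In a functional assay on DLD-1 cells (Homo sapiens) for antiproliferative activity, read by CellTiter-Glo, with a stated time of 72 h (on this read-out higher numbers stand for weaker inhibition and lower numbers for stronger inhibition), compound 1 stands second highest of the three numbers. Its nearest neighbour is compound 2: a 3.1-fold lower number from compound 1 to compound 2 (0.49 log units; beyond the scatter). Its furthest is compound 3: a 330-fold higher number from compound 1 to compound 3 (2.52 log units; beyond the scatter). Between the other two the gap is large: a 1000-fold higher number from compound 2 to compound 3 (3.02 log units; beyond the scatter).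

The unmeasured compound 4, `CC1CCN(C2CCN(S(=O)(=O)c3ccc(Cl)c(Cl)c3)CC2)CC1`, changes compound 1 in one place: 3,4-dichlorophenyl in place of 2-bromophenyl on a sulfonyl sulfur. For the measured compounds named here, none of the measured steps touches this kind of change; each of them alters the bromo itself or adds a methoxy to a phenyl. They show only that this position tolerates some groups and punishes others severely, as compound 3 makes plain. Going by the values given here, with no direct precedent, compound 4 is expected to give a number close to compound 1, perhaps somewhat higher, and a wide range is warranted: the estimated step is a 3.3-fold higher number from compound 1 to compound 4 (0.52 log units; beyond the scatter). The estimated value for compound 4 in this assay is 10 nM, with a range from 2 nM to 100 nM.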

Compound 4, half-maximal inhibitory concentration: 2.9 nM
The estimate for compound 4 lay 3.4-fold (0.54 log units) above the measured number; the range from low to high includes it.
By their numbers in this assay, from the lowest: compound 2; then compounds 4 and 1 (each within the scatter of the next); then compound 3.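

Replacing 2-bromophenyl with 3,4-dichlorophenyl on the sulfonyl sulfur leaves the reading in this assay unchanged within the scatter (a 1.0-fold lower number from compound 1 to compound 4 (0.01 log units; within the scatter)), so the two compounds cannot be told apart here. The earlier steps shown here changed only what stood in place of the bromo or added a methoxy, whereas this step replaces the whole aromatic group, showing that a different halogen pattern on the phenyl ring can still match compound 1. Nothing available explains why the two compounds read alike.

On these data alone, it remains open whether a single chlorine, a nitrile or a carboxylic acid on the phenyl ring would also match compound 1. Also unsettled is how a 4-methoxyphenyl group attached directly to the sulfonyl sulfur would read.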